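The source may report more compounds than this note shows. Statements on the series, on what has been measured and on what is new or still open speak of the compounds shown alone.

For the measured compounds named here, compound 1 `CCCCCCCN1C(=N)NC[C@@H]1CCCCN1C[C@@H](Cc2ccccc2)N(CC2CCC(C(C)(C)C)CC2)C1=N` and compound 2 `CCCCCCCN1C(=N)NC[C@@H]1CCCCN1C[C@@H](CC2CCCCC2)N(CC2CCC(C(C)(C)C)CC2)C1=N` are the two measured members. In an assay on HEK293 cells for displacement of a labelled ligand from Neuronal acetylcholine receptor; alpha4/beta2 (Rattus norvegicus), with a stated time of 2 h (a lower number here means a stronger inhibitor, a higher number a weaker inhibitor), compound 1 gives 2700 nM and compound 2 gives 3900 nM; a 1.4-fold higher number from compound 1 to compound 2 (0.16 log units; within the scatter), so the two stand within the scatter of each other. Compound 3 `CC(C)CCCN1C(=N)NC[C@@H]1CCCCN1C[C@@H](Cc2ccccc2)N(CC2CCC(C(C)(C)C)CC2)C1=N` differs from compound 1 by isopropyl in place of butyl on a saturated chain carbon, three bonds along the chain from an amine nitrogen in a ring: the heptyl chain becomes 4-methylpentyl. Going by the values given here, no measured step touches this chain, and the single step in hand concerns another part of the core. The expected step of a 1.1-fold higher number from compound 1 to compound 3 (0.05 log units; within the scatter) is therefore none beyond the scatter. Compound 3 is estimated at 3000 nM, range 1200 nM to 8000 nM.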

Compound 3, inhibition constant: 2300 nM
For compound 3 the middle estimate is 1.3-fold (0.12 log units) above the measured one; the range from low to high includes it.
By their numbers in this assay, from the lowest: compounds 3, 1 and 2 (each within the scatter of the next).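

In this assay, for the compounds shown here, the first measured step on this chain, heptyl to 4-methylpentyl, gives a 1.2-fold lower number from compound 1 to compound 3 (0.07 log units; within the scatter) and so leaves the two compounds within the scatter of each other. Isopropyl in place of butyl at this position therefore brings no readable change, a point the earlier step, made elsewhere on the core, could not show. No available evidence bears on this result.

Still open, from the compounds shown here alone, is whether a longer chain would stay within the scatter. The same applies to a chain ending in an amine or a carboxylic acid.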